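The source may hold more compounds than are shown below. What is called first, only, known or untested is meant among the compounds shown, and "the series" means these compounds.

Going by the values given here, in a toxicity assay on Vero cells (Chlorocebus sabaeus) for cytotoxicity, read by MTT assay (a higher number here means a weaker inhibitor, a lower number a stronger inhibitor), compound 2 `COC(=O)NC(=O)c1ccsc1NC(=O)c1ccc(S(=O)(=O)N2CCCC2)cc1` gives 39.5 ug/mL, the higher of the two numbers so far, while compound 1 `COC(=O)NC(=O)c1ccsc1NC(=O)c1ccc(S(=O)(=O)N2CCC2)cc1` gives 17.5 ug/mL. Compound 3 `COC(=O)NC(=O)c1ccsc1NC(=O)c1ccc(S(=O)(=O)N2CCCCCC2)cc1` is not yet measured and differs from compound 2 as follows: azepan-1-yl in place of pyrrolidin-1-yl on a sulfonyl sulfur. Among the compounds with values here, only one measured step bears on this change, at the same place on a sulfonyl sulfur: a 2.3-fold higher number from compound 1 to compound 2 (0.35 log units; beyond the scatter). As far as these compounds go, one modest step sets no firm trend, so no step beyond the scatter is expected in this assay, and the direction remains open. The expected step is a 1.0-fold higher number from compound 2 to compound 3 (0.01 log units; within the scatter). For compound 3 the estimate is 40 ug/mL, with an expected range of 15 ug/mL to 100 ug/mL.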

Compound 3, half-maximal inhibitory concentration: 9.13 ug/mL
For compound 3 the middle estimate is 4.4-fold (0.64 log units) above the measured one, outside the stated range (below it).
By their numbers in this assay, from the lowest: compounds 3 and 1 (each within the scatter of the next); then compound 2.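

In this assay, going by these compounds alone, the ring on the sulfonyl sulfur gives no steady trend with size: a 4.3-fold lower number from compound 2 to compound 3 (0.64 log units; beyond the scatter) runs against a 2.3-fold higher number from compound 1 to compound 2 (0.35 log units; beyond the scatter) and leaves compound 2 with the highest number of the series so far. Azepan-1-yl and azetidin-1-yl are not separated, with a 1.9-fold lower number from compound 1 to compound 3 (0.28 log units; within the scatter) as their printed difference. No supporting data account for this reversal at pyrrolidin-1-yl. As far as these compounds go, whether piperidin-1-yl would sit with compound 2 or with the other two stays open. From the compounds shown here alone, the outcome with morpholin-4-yl or an open-chain diethylamino group on the sulfonyl sulfur is also open.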